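Benzyl to methoxyethyl on the core nitrogen

A few compounds are considered here, and "the series" means these few. Any claim that something is new, unique, unknown or untested is made for them only; others in the source may bear on it.

Compound 1 `CCn1c(CN2CCN(c3nc(C(F)(F)F)ccc3Cl)CC2)nc2ccccc21`: 63.1 nM
Compound 2 `FC(F)(F)c1ccc(Cl)nc1N1CCN(Cc2nc3ccccc3n2Cc2ccccc2)CC1`: 126 nM
Compound 3 `Cn1c(CN2CCN(c3nc4ccccc4s3)CC2)nc2ccccc21`: 316 nM

Of the compounds shown here, three have been measured in an assay on CHO cells with metabotropic glutamate receptor 2 (Homo sapiens) as the target, read by FLIPR; on this read-out higher numbers stand for an effect only at larger amounts of compound and lower numbers for an effect already at smaller amounts. Compound 2 `FC(F)(F)c1ccc(Cl)nc1N1CCN(Cc2nc3ccccc3n2Cc2ccccc2)CC1` gives 126 nM, the second highest of the three numbers. The nearest is compound 1, whose value of 63.1 nM lies within the scatter of that of compound 2, so the two cannot be told apart. Compound 3, with 316 nM, gives a higher number than compound 2, and that gap lies beyond the scatter.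

Compound 4 `COCCn1c(CN2CCN(c3nc(Cl)ccc3C(F)(F)F)CC2)nc2ccccc21` has not yet been measured. It differs from compound 2 as follows: methoxymethyl in place of phenyl on a saturated chain carbon bound to an aromatic nitrogen. Going by the values given here, compound 1 carries a small saturated group on the same aromatic nitrogen and gives 63.1 nM, but its other ring is arranged differently, so no step between measured compounds isolates the change.

On that basis the step from compound 2 to compound 4 is expected to stay within the scatter, a 1.4-fold lower number from compound 2 to compound 4 (0.15 log units; within the scatter). Compound 4 is therefore estimated at 90 nM, in a range from 30 nM to 300 nM.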

Compound 4, half-maximal effective concentration: 158 nM
For compound 4 the middle estimate is 1.8-fold (0.24 log units) below the measured one; the measured number falls inside the stated range.
By their numbers in this assay, from the lowest: compounds 1, 2, 4 and 3 (each within the scatter of the next, the first and the last beyond it).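

Going by these compounds alone, on the saturated chain carbon bound to an aromatic nitrogen, the change from benzyl to 2-methoxyethyl gives the first step that can be read in this assay, with a 1.3-fold higher number from compound 2 to compound 4 (0.10 log units; within the scatter). Compounds 2 and 4 therefore cannot be told apart, so at this place a phenyl with its six-membered aromatic ring and a methoxymethyl with no ring and one hydrogen-bond acceptor are interchangeable on this read-out. Nothing available here bears on why the two numbers stay so close.

What the compounds shown leave open is whether an amine, a carboxylic acid or a longer chain on the same carbon would also leave the number within the scatter. As far as these compounds go, it is equally open whether this step would read the same on the differently arranged ring of compound 1.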